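The compounds below may be only part of what the source reports. "The series", "measured", "known", "first", "only" and "open" are said of these compounds alone.

In a functional assay on HT-29 cells (Homo sapiens) for cytotoxicity, read by sulforhodamine B assay (a higher number here means a weaker inhibitor, a lower number a stronger inhibitor), three compounds that share one core and differ in the group on an amine nitrogen have been measured. Compound 1 `C=C1[C@@H](OC(C)=O)C[C@@H]2[C@](C)(CO[Si](C)(C)C(C)(C)C)[C@H](OC(C)=O)CC[C@@]2(C)[C@@H]1C[C@@H](Nc1ccc(F)cc1)C1=CCOC1=O`, with 4-fluorophenyl there, gives 4940 nM. Compound 2 `C=C1[C@@H](OC(C)=O)C[C@@H]2[C@](C)(CO[Si](C)(C)C(C)(C)C)[C@H](OC(C)=O)CC[C@@]2(C)[C@@H]1C[C@@H](Nc1ccccc1F)C1=CCOC1=O`, with 2-fluorophenyl, gives 3710 nM. Compound 3 `C=C1[C@@H](OC(C)=O)C[C@@H]2[C@](C)(CO[Si](C)(C)C(C)(C)C)[C@H](OC(C)=O)CC[C@@]2(C)[C@@H]1C[C@@H](Nc1ccccc1C(=O)O)C1=CCOC1=O`, with 2-carboxyphenyl, gives 5340 nM, which places it within the scatter of both others.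

Compound 4 `C=C1[C@@H](OC(C)=O)C[C@@H]2[C@](C)(CO[Si](C)(C)C(C)(C)C)[C@H](OC(C)=O)CC[C@@]2(C)[C@@H]1C[C@@H](Nc1ccc(C(=O)O)cc1)C1=CCOC1=O` has not been measured yet. It differs from compound 3 only at that amine nitrogen: 4-carboxyphenyl in place of 2-carboxyphenyl on an amine nitrogen. In words, this is 4-carboxyphenyl in place of 2-carboxyphenyl on an amine nitrogen.

Going by the values given here, no measured pair moves a carboxy group, so the closest guide is the pair that moves fluoro. Putting 2-fluorophenyl in place of 4-fluorophenyl gave a 1.3-fold lower number from compound 1 to compound 2 (0.12 log units; within the scatter). Putting carboxy in place of fluoro gave a 1.4-fold higher number from compound 2 to compound 3 (0.16 log units; within the scatter), and 2-carboxyphenyl in place of 4-fluorophenyl gave a 1.1-fold higher number from compound 1 to compound 3 (0.03 log units; within the scatter). All three steps are small, so no change beyond the scatter is expected in this assay, and the data favour no clear direction. The expected step is a 1.2-fold lower number from compound 3 to compound 4 (0.06 log units; within the scatter), which stays within the scatter. The estimate for compound 4 is 4600 nM, with an expected range from 2500 nM to 8500 nM.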

Compound 4, half-maximal inhibitory concentration: 4630 nM
For compound 4 the middle estimate is 1.0-fold (0.00 log units) below the measured one; low and high end bracket the measured number.
By their numbers in this assay, from the lowest: compounds 2, 4, 1 and 3 (each within the scatter of the next).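

Moving the carboxy group on the amine nitrogen, as 4-carboxyphenyl in place of 2-carboxyphenyl, gives a 1.2-fold lower number from compound 3 to compound 4 (0.06 log units; within the scatter) in this assay, so a shift of the carboxy group can now be read directly, and like the shift of the fluoro group it stays within the scatter. Changing the group itself reads the same way, with a 1.2-fold higher number from compound 2 to compound 4 (0.10 log units; within the scatter) for 4-carboxyphenyl in place of 2-fluorophenyl and a 1.1-fold lower number from compound 1 to compound 4 (0.03 log units; within the scatter) for carboxy in place of fluoro on an aromatic carbon, so no step among these four compounds separates them. Carboxy in place of fluoro can now be read twice, and the two readings do not separate from each other: the same change on two cores in this assay, a 1.4-fold higher number (0.16 log units; within the scatter) from compound 2 to compound 3 and a 1.1-fold lower number (0.03 log units; within the scatter) from compound 1 to compound 4, 1.5-fold (0.19 log units) apart, within the scatter of two such steps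

On these data alone, all four compounds carry a phenyl ring with fluoro or carboxy on the amine nitrogen, so it remains open whether an unsubstituted phenyl, a methoxyphenyl, a pyridine or a simple alkyl chain there would step beyond the scatter. The shared core is also the same throughout, which leaves open what a free hydroxyl in place of its silyl ether would do to the number.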